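From compound 3 to compound 4: a pyridine swap

This account rests on a few compounds, and the source may have more. Where it says the series, first, only, none or still open, it means among the compounds named here.

Among the measured compounds shown here, in a functional assay on NFS-60 cells (Mus musculus) for inhibition, with a stated time of 72 h (a higher number here means a weaker inhibitor of growth, a lower number a stronger inhibitor of growth), compound 3 `Nc1ncnc2c(C(=O)Nc3cccc4c3c(Br)nn4Cc3ccncc3)csc12` gives 135 nM, the lowest number of the three measured so far. Compound 1 `Nc1ncnc2c(C(=O)Nc3cccc4c3c(Br)nn4Cc3ccccc3)csc12` gives 1010 nM, and compound 2 `Nc1ncnc2c(C(=O)Nc3cccc4c3c(Br)nn4Cc3ccccn3)csc12` gives 2500 nM. Compound 4 `Nc1ncnc2c(C(=O)Nc3cccc4c3c(Br)nn4Cc3cccc(Br)n3)csc12` is not yet measured. Its change is 6-bromopyridin-2-yl in place of pyridin-4-yl on a saturated chain carbon bound to an aromatic nitrogen.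

The step bearing most directly on this is a 19-fold lower number from compound 2 to compound 3 (1.27 log units; beyond the scatter), a large one, and compound 4 would run against it, as its ring is again a pyridin-2-yl, now carrying bromine. The modest steps of a 2.5-fold higher number from compound 1 to compound 2 (0.39 log units; beyond the scatter) and a 7.5-fold lower number from compound 1 to compound 3 (0.87 log units; beyond the scatter) show that the choice of ring moves the number in either direction. For the measured compounds named here, no measured compound shows the effect of the added bromine, so the range stays wide.

A large step to a higher number is expected in this assay, estimated as an 11-fold higher number from compound 3 to compound 4 (1.05 log units; beyond the scatter). For compound 4 the estimated value is 1500 nM, with an expected range of 400 nM to 5000 nM.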

Compound 4, concentration for 50% growth inhibition: 243 nM
Compound 4: middle estimate off by 6.2-fold (0.79 log units), on the high side; measured number outside the range, below it.
By their numbers in this assay, from the lowest: compounds 3 and 4 (each within the scatter of the next); then compound 1; then compound 2.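

Adding bromo to the pyridin-2-yl ring in this assay gives a large change (a 10-fold lower number from compound 2 to compound 4 (1.01 log units; beyond the scatter)), so a pyridin-2-yl on this saturated chain carbon does not by itself fix a high number. The 6-bromopyridin-2-yl group also stands clear of phenyl (a 4.2-fold lower number from compound 1 to compound 4 (0.62 log units; beyond the scatter)), while the two pyridine groups of the latest pair cannot be ordered (a 1.8-fold higher number from compound 3 to compound 4 (0.26 log units; within the scatter)), which makes 6-bromopyridin-2-yl and pyridin-4-yl equally good starting points at this position on the present numbers. Nothing at hand explains the effect of the added bromine.

The compounds shown leave open whether this gain is specific to bromine, or whether chloro, methyl or an amine in its place on the pyridin-2-yl ring would do the same. They also leave open what bromo does on the pyridin-4-yl or phenyl rings.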